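Series notes: metabolic stability of cinnamamide-bearing compounds

The compounds below may be only part of what the source reports. "The series", "measured", "known", "first", "only" and "open" are said of these compounds alone.

For the measured compounds named here, compound 1 `Cc1nc(N2CCC(N3CCCC3=O)CC2)nc2ccc(NC(=O)/C=C/c3ccc(Cl)cc3)cc12` is the only member with a number in an ADME assay on microsomes from liver (Homo sapiens) for metabolic stability, with a stated time of 30 min; on this read-out higher numbers stand for a more stable compound and lower numbers for a less stable compound: in this assay compound 1 gives 50%. Compound 2 `Cc1nc(NCCNC(=O)C2CC2)nc2ccc(NC(=O)/C=C/c3ccc(OC(F)(F)F)cc3)cc12` is recorded in this assay as "not determined" (no result reported), so compound 2 stands nowhere on the numbers shown and offers no anchor of its own. Compound 3 `Cc1nc(N2CCC(N3CCNC3=O)CC2)nc2ccc(NC(=O)/C=C/c3ccc(OC(F)(F)F)cc3)cc12` has not been measured in this assay. The change from compound 2 to compound 3 is 4-(2-oxoimidazolidin-1-yl)piperidin-1-yl in place of (2-((cyclopropylcarbonyl)amino)ethyl)amino on an aromatic carbon. Since compound 2 has no value, the size of the step from compound 2 to compound 3 in this assay cannot be set against a measured number, and no direction is claimed for it beyond the usual scatter. The expectation for compound 3 therefore rests on compound 1, which gives 50% in this assay. Compound 3 is estimated at 45% in this assay, within a range from 20% to 75%.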

Compound 3, percent of the compound remaining: 83%
Compound 3: the middle estimate sits 38 percentage points below what was measured, and the stated range ends below it.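

No new step can be read for compound 3 in this assay, as compound 2 has no value to set against it. Still open, from the compounds shown here alone, is what exchanging (2-((cyclopropylcarbonyl)amino)ethyl)amino for 4-(2-oxoimidazolidin-1-yl)piperidin-1-yl does in this assay on the shared core. No evidence bears on this result.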